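Adding a chlorine where a methoxy once mattered

The compounds below may be only part of what the source reports. "The series", "measured", "known", "first", "only" and "open" are said of these compounds alone.

Three compounds share one core and were tested in an assay on HEK293 cells for positive allosteric modulation of metabotropic glutamate receptor 2 (Rattus norvegicus), read by thallium flux, with a stated time of 2.5 min; a higher number here means that more compound is needed for the effect, a lower number that less compound is needed. Compound 2, with structure `COc1cc(C(=O)O)ccc1OCCCCOc1ccc(C(=O)CC(C)C)c(O)c1C`, gives 40 nM. Compound 3, with structure `Cc1c(OCCCCOc2ccc(C(=O)O)cc2)ccc(C(=O)CC(C)C)c1O`, gives 122 nM. Compound 1, with structure `Cc1c(OCCCCOc2ccc(C(=O)O)cc2Cl)ccc(C(=O)CC2CCCC2)c1O`, gives 237 nM. Among the compounds with values here, compound 3 thus stands second highest of the three numbers: the gap to compound 1 lies within the scatter, while the gap to compound 2 lies beyond it, as the single measured step shows: a 3.1-fold higher number from compound 2 to compound 3 (0.48 log units; beyond the scatter).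

The next compound, compound 4, with structure `Cc1c(OCCCCOc2ccc(C(=O)O)cc2Cl)ccc(C(=O)CC(C)C)c1O`, differs from compound 3 in one place: chloro in place of hydrogen on an aromatic carbon. Within the data shown here, this is the same position at which compound 2 carries its methoxy, so the step from compound 2 to compound 3 is the one measurement that bears on it, and it says that taking a group away from that position raised the number modestly. Compound 1 also carries a chloro there, but it differs from compound 3 in a second place as well, so its value only hints that chloro at that site is compatible with a number of the same order as compound 3. A modest lowering is therefore expected, and the step from compound 3 to compound 4 in this assay is estimated as a 1.5-fold lower number from compound 3 to compound 4 (0.18 log units; within the scatter), giving compound 4 an expected value of 80 nM, with a range from 35 nM to 200 nM.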

Compound 4, half-maximal effective concentration: 96 nM
For compound 4 the middle estimate is 1.2-fold (0.08 log units) below the measured one; the measured number falls inside the stated range.
By their numbers in this assay, from the lowest: compound 2; then compounds 4, 3 and 1 (each within the scatter of the next, the first and the last beyond it).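

In this assay, chloro in place of hydrogen on this aromatic carbon gives a 1.3-fold lower number from compound 3 to compound 4 (0.10 log units; within the scatter), so the two groups cannot be told apart here, and adding an atom at this site does not by itself bring the number down. Chloro in place of methoxy gives a 2.4-fold higher number from compound 2 to compound 4 (0.38 log units; beyond the scatter), which, read with the step between compound 2 and compound 3, sets methoxy apart from both hydrogen and chloro among the three groups seen at this position. Within the data shown here, with chloro held fixed, the change at the other end of the molecule can now be read alone for the first time: isopropyl in place of cyclopentyl gives a 2.5-fold lower number from compound 1 to compound 4 (0.39 log units; beyond the scatter), so that site matters more in this pair than hydrogen versus chloro does in the pair of compound 3 and compound 4.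

Nothing available here accounts for why methoxy stands apart from the other two groups. As far as these compounds go, whether an ethoxy, a hydroxy or a fluoro at this position would fall with methoxy or with hydrogen and chloro stays open, as does whether methoxy would keep its place in a compound carrying cyclopentyl instead of isopropyl.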